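A few compounds are considered here, and "the series" means these few. Any claim that something is new, unique, unknown or untested is made for them only; others in the source may bear on it.

Compound 1 `CC(NC(=O)CCc1ccc(NC(=O)Nc2ccc(Cl)c(C(F)(F)F)c2)cc1)c1ccccc1`: > 50000 nM (a limit)
Compound 2 `O=C(CCc1ccc(NC(=O)Nc2ccc(Cl)c(C(F)(F)F)c2)cc1)NC1CCC1`: > 50000 nM (a limit)
Compound 3 `CNC(=O)CCc1ccc(NC(=O)Nc2ccc(Cl)c(C(F)(F)F)c2)cc1`: 21000 nM

Compound 3 alone gives a true number in a functional assay on HepG2 cells (Homo sapiens) for inhibition, read by MTT assay, with a stated time of 120 h; on this read-out higher numbers stand for weaker inhibition and lower numbers for stronger inhibition. The rest of the evidence is the limit of > 50000 nM in this assay, at which 2 of the 3 values shown sit.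

Compound 4 `CC1CN(C(=O)CCc2ccc(NC(=O)Nc3ccc(Cl)c(C(F)(F)F)c3)cc2)CC(C)O1` has 2,6-dimethylmorpholin-4-yl in place of methylamino on a carbonyl carbon.

Among the compounds with values here, two measured steps bear on this change: an at least 2.3-fold lower number from compound 1 to compound 3 (0.37 log units; beyond the scatter) and an at least 2.3-fold lower number from compound 2 to compound 3 (0.37 log units; beyond the scatter). In each, methyl comes in and the number falls. Compound 4 gives up that methyl for a ring, so the opposite direction is expected, with a modest rise that may well reach the limit of the assay.

The expected change is a 2.4-fold higher number from compound 3 to compound 4 (0.38 log units; beyond the scatter).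

The estimated value for compound 4 is 50000 nM, with an expected range of 22000 nM to 100000 nM.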

Compound 4, half-maximal inhibitory concentration: > 50000 nM
Compound 4 ended at the assay's limit; the forecaster's own chance of this, stated with the estimate: 60%; the middle value lies on the limit itself.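

In this assay the swap to 2,6-dimethylmorpholin-4-yl gives an at least 2.3-fold higher number from compound 3 to compound 4 (0.37 log units; beyond the scatter), which shows that a ring lacking the amide hydrogen also ends at a limit on this carbonyl carbon. The steps from compound 1 and compound 2 to compound 4 cannot be read; both ends are limits. Methylamino remains the only group here with a true number: the limit of > 50000 nM in this assay, at which 3 of the 4 values shown sit.

Compound 4 brings in a ring and loses the amide hydrogen together, so the two changes stay unseparated. On these data alone, whether a plain amino group or a dimethylamino group would give a lower number than compound 3 remains open.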